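The source may report more compounds than this note shows. Statements on the series, on what has been measured and on what is new or still open speak of the compounds shown alone.

In an ADME assay on 184B5 cells (Homo sapiens) for cytotoxicity, read by MTT assay, with a stated time of 72 h (on this read-out lower numbers stand for stronger inhibition of growth and higher numbers for weaker inhibition of growth), three compounds have been measured so far:

compound 1, `CCCCC[Se]c1nc(NCc2ccccc2)c2ccccc2n1`, gives 70900 nM;
compound 2, `[SeH]c1nc(NCc2ccccc2)c2ccccc2n1`, gives 20800 nM;
compound 3, `Nc1nc([SeH])nc2ncccc12`, gives 5200 nM.

Compound 1 and compound 2 share a core and differ in one place only, by pentyl in place of hydrogen on a selenium. This change gave a 3.4-fold higher number from compound 2 to compound 1 (0.53 log units; beyond the scatter), so the longer chain went with weaker inhibition of growth. Compound 3 has a different core; how the core of compound 3 differs from that of compound 2 is not broken down here. Among the three, compound 3 gives the lowest number, and both of its gaps to the others lie beyond the usual scatter.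

Compound 4, `CCCCC[Se]c1nc(N)c2cccnc2n1`, has not yet been measured in this assay. It differs from compound 3 by pentyl in place of hydrogen on a selenium, the same change, at the same place, as that from compound 2 to compound 1. For the measured compounds named here, the expected step from compound 3 to compound 4 is a 3.3-fold higher number from compound 3 to compound 4 (0.51 log units; beyond the scatter), close to the earlier one, because a 3.4-fold higher number from compound 2 to compound 1 (0.53 log units; beyond the scatter) is the only measurement of this change here and it sits on a different core. Compound 4 is therefore expected to give about 17000 nM in this assay, most likely between 7000 nM and 45000 nM.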

Compound 4, concentration for 50% growth inhibition: 10300 nM
The estimate for compound 4 lay 1.7-fold (0.22 log units) above the measured number, and the stated range covers the measured number.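

In this assay, pentyl in place of hydrogen on a selenium gave a 2.0-fold higher number from compound 3 to compound 4 (0.30 log units; within the scatter), so on this core the change alone cannot be told apart from the differences seen between repeated measurements. Set beside the same change on the other core, the two steps cannot be told apart either: the same change on two cores in this assay, a 3.4-fold higher number (0.53 log units; beyond the scatter) from compound 2 to compound 1 and a 2.0-fold higher number (0.30 log units; within the scatter) from compound 3 to compound 4, 1.7-fold (0.24 log units) apart, within the scatter of two such steps. This fits the change carrying over from one core to the other with a similar size, but it rests on just two pairs of compounds, one of whose steps is within the scatter, so it neither shows that the size is fixed nor says how the change would behave on a third core.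

The compounds shown leave open what other groups on the selenium would do, such as methyl, a longer chain like octyl, or a chain ending in an amine or a carboxylic acid. They also leave open whether the number rises steadily with chain length, since pentyl is the only chain here.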